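The compounds below may be only part of what the source reports. "The series", "measured", "known", "first", "only" and "open" are said of these compounds alone.

Measured so far:
compound 1, `Cc1nnc(CNC(=O)CN)n1-c1ccc(Cl)cc1C(=O)c1ccccc1F` — in a functional assay on the whole organism with Mus musculus as the target (a higher number here means that more compound is needed for the effect, a lower number that less compound is needed), compound 1 gives 0.25 mg/kg
compound 2, `CN(C(=O)CNC(=O)CN)c1ccc(Cl)cc1C(=O)c1ccccc1Cl` — in this assay compound 2 gives 0.8 mg/kg

Of the two measured compounds, compound 2 has the higher number in this assay, so more of compound 2 is needed for the effect than of compound 1, and the gap between them lies beyond the usual scatter of this assay. Compound 2 is now the starting point for a single change. Compound 3, `CN(C(=O)CNC(=O)CN)c1ccc(Cl)cc1C(=O)c1ccccc1`, has not yet been measured. It differs from compound 2 in one place only: hydrogen in place of chloro on an aromatic carbon. The change thus takes a chloro group off the 2-chlorophenyl part of the shared core and leaves a plain phenyl there.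

For the measured compounds named here, with no comparable step between measured compounds to lean on, the size of the change to expect in this assay is uncertain. The step from compound 2 to compound 3 is expected to be modest and toward a higher number, that is a 2.5-fold higher number from compound 2 to compound 3 (0.40 log units; beyond the scatter). For compound 3 the estimate in this assay is 2 mg/kg, within a range from 0.7 mg/kg to 6 mg/kg.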

Compound 3, dose for half-maximal effect: 5.2 mg/kg
For compound 3 the middle estimate is 2.6-fold (0.41 log units) below the measured one, and the stated range covers the measured number.
By their numbers in this assay, from the lowest: compound 1; then compound 2; then compound 3.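

For the compounds shown here, this is the first pair here that differs in one place only, so it gives a direct reading of what the chloro group on the 2-chlorophenyl part is worth in this assay on this core. Taking it off and leaving a plain phenyl gives a 6.5-fold higher number from compound 2 to compound 3 (0.81 log units; beyond the scatter), so more compound is needed for the effect without the chloro group. One chlorine atom, with no hydrogen-bond donor or acceptor and no net charge, is therefore enough to move the number beyond the usual scatter, and nothing measured here bears on the reason for this shift.

On these data alone, whether a fluoro, methyl or methoxy group at this same place would match chloro stays open. Also open, as far as these compounds go, is whether removing the chloro group would have a similar effect on another core.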